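Swapping 4-methoxybenzyl for 3-methylbut-2-en-1-yl on the shared core

This account rests on a few compounds, and the source may have more. Where it says the series, first, only, none or still open, it means among the compounds named here.

In a functional assay on BT-474 cells (Homo sapiens) for inhibition, read by fluorescence, with a stated time of 72 h (a higher number here means a weaker inhibitor of growth, a lower number a stronger inhibitor of growth), compound 1 (`CC(C)CCn1cnc2c(Nc3ccc(Cl)cc3)nc(N[C@H]3CC[C@H](N)CC3)nc21`) gives 5100 nM and compound 2 (`COc1ccc(Cn2cnc3c(Nc4cccc(Cl)c4)nc(N[C@H]4CC[C@H](N)CC4)nc32)cc1`) gives 8200 nM so that the two stand within the scatter of each other. Compound 3 (`CC(C)=CCn1cnc2c(Nc3cccc(Cl)c3)nc(N[C@H]3CC[C@H](N)CC3)nc21`) is still unmeasured. It departs from compound 2 by one change (2-methylprop-1-en-1-yl in place of 4-methoxyphenyl on a saturated chain carbon bound to an aromatic nitrogen) with 2-methylprop-1-en-1-yl in place of 4-methoxyphenyl on a saturated chain carbon bound to an aromatic nitrogen, which reads as 4-methoxybenzyl to 3-methylbut-2-en-1-yl. Within the data shown here, no measured step isolates this change. Compound 1 also lacks the 4-methoxybenzyl group and, at 5100 nM in the same test, stays within the scatter of compound 2, although those two differ in more than one place. No shift beyond the scatter is therefore expected in this assay in either direction. The estimated step is a 1.5-fold lower number from compound 2 to compound 3 (0.17 log units; within the scatter) and stays within the scatter. Compound 3 is expected at 5500 nM with an estimated range from 2000 nM to 14000 nM in repeated measurements.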

Compound 3, concentration for 50% growth inhibition: 7000 nM
Compound 3: the middle estimate sits 1.3-fold (0.10 log units) below what was measured, and the stated range covers the measured number.
By their numbers in this assay, from the lowest: compounds 1, 3 and 2 (each within the scatter of the next).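

In this assay, among these compounds, the change from 4-methoxybenzyl to 3-methylbut-2-en-1-yl gives a 1.2-fold lower number from compound 2 to compound 3 (0.07 log units; within the scatter), and this is the first measured step that isolates a change on a saturated chain carbon bound to an aromatic nitrogen. At this place, then, replacing 4-methoxyphenyl with 2-methylprop-1-en-1-yl removes the six-membered aromatic ring and the hydrogen-bond acceptor without a shift beyond the scatter. Nothing measured here gives a reason for this result.

The compounds shown leave open whether an amine, a carboxylic acid or a longer chain at this place would move the number beyond the scatter. Compound 1 differs from the other two in more than one place, so it gives no separate reading of any single change.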